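Cyclohexyl for Methyl on the Ring Nitrogen

The compounds below may be only part of what the source reports. "The series", "measured", "known", "first", "only" and "open" are said of these compounds alone.

Compound 1 `Cc1[nH]c(=O)n(C)c1-c1ccc(OCCC(C)C)cc1`: 6600 nM
Compound 2 `Cc1[nH]c(=O)n(C)c1-c1ccc(-c2ccccc2)cc1`: 6300 nM

Both compounds were measured in a functional assay on brain (Rattus norvegicus, strain Wistar) for inhibition; on this read-out higher numbers stand for weaker inhibition and lower numbers for stronger inhibition. Compound 2 gives the lower of the two numbers, but the step of a 1.0-fold lower number from compound 1 to compound 2 (0.02 log units; within the scatter) is within the scatter, so the two compounds cannot be told apart on this read-out. Compound 3 `Cc1[nH]c(=O)n(C2CCCCC2)c1-c1ccc(-c2ccccc2)cc1` has not been measured. It differs from compound 2 by cyclohexyl in place of methyl on an aromatic nitrogen. Within the data shown here, the one measured step, a 1.0-fold lower number from compound 1 to compound 2 (0.02 log units; within the scatter), concerns a change on the aromatic carbon and does not touch the aromatic nitrogen, so no measured step bears on the present change. With nothing pointing in either direction, a step of a 1.1-fold lower number from compound 2 to compound 3 (0.02 log units; within the scatter) of no clear direction beyond the scatter is expected, with a wide range around it. Compound 3 is therefore estimated at 6000 nM, between 1500 nM and 25000 nM, in this assay.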

Compound 3, half-maximal inhibitory concentration: 10900 nM
Compound 3: the middle estimate sits 1.8-fold (0.26 log units) below what was measured, and the stated range covers the measured number.
By their numbers in this assay, from the lowest: compounds 2, 1 and 3 (each within the scatter of the next).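

On this assay the aromatic nitrogen takes cyclohexyl in place of methyl with a 1.7-fold higher number from compound 2 to compound 3 (0.24 log units; within the scatter) so compound 2 and compound 3 cannot be told apart on this read-out. Among these compounds, this is the first measured change at this position, and it shows that six heavy atoms with a non-aromatic ring can stand there in place of one, with the number still within the scatter of that of compound 2. No evidence is at hand that would account for this result.

What the compounds shown leave open is how a benzyl group, a longer chain or a carboxylic acid on this ring nitrogen would read. They also leave open whether cyclohexyl gives the same picture when isopentyloxy replaces the phenyl on the aromatic carbon.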